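Bromo to methylsulfanyl on the core of compound 2

The source may report more compounds than this note shows. Statements on the series, on what has been measured and on what is new or still open speak of the compounds shown alone.

Measured so far in a functional assay on cells (Hepatocyte, Mus musculus), with a stated time of 6 h; a higher number here means that more compound is needed for the effect, a lower number that less compound is needed:
- compound 1 `O=C(Nc1ncc(Br)s1)NS(=O)(=O)c1cccc(Cl)c1` with 49000 nM
- compound 2 `CNC(=O)Nc1cc(Br)cc(NC(=O)NS(=O)(=O)c2cc(C)c(CCOC)s2)n1` with 5000 nM

Of these two, compound 2 has the lower number, and the gap to compound 1 lies beyond the usual scatter. The two differ in many places, so that gap says nothing about any single group.

The next compound is compound 3 `CNC(=O)Nc1cc(SC)cc(NC(=O)NS(=O)(=O)c2cc(C)c(CCOC)s2)n1`, which carries methylsulfanyl in place of bromo on an aromatic carbon, opposite the ring nitrogen (methylsulfanyl in place of bromo on an aromatic carbon). Among the measured compounds shown here, no measured pair shows this exchange or any other single change, so the data offer no direct guide. The expectation in this assay is therefore a modest step with no firm direction, most likely none beyond the scatter. The estimate means a 1.1-fold lower number from compound 2 to compound 3 (0.05 log units; within the scatter) as the expected step. For compound 3 the estimated value is 4500 nM (expected range 1500 nM to 14000 nM).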

Compound 3, half-maximal effective concentration: 8000 nM
The estimate for compound 3 lay 1.8-fold (0.25 log units) below the measured number; the range from low to high includes it.
By their numbers in this assay, from the lowest: compounds 2 and 3 (each within the scatter of the next); then compound 1.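

Among the compounds shown here, on the shared core, at the aromatic carbon opposite the ring nitrogen, putting methylsulfanyl in place of bromo gives in this assay a 1.6-fold higher number from compound 2 to compound 3 (0.20 log units; within the scatter) as the only single-place comparison available. The earlier pair differed in too many places to say anything about one group, whereas this step shows that, in this one setting, the assay does not separate bromo from methylsulfanyl at this position. The data shown offer no measurement that could explain this result.

On these data alone, it remains open whether an amine, a methoxy group or a longer chain such as ethylsulfanyl at this position would give a step beyond the scatter. Also open, as far as these compounds go, is whether the same exchange would read alike with a different group in place of the methylcarbamoylamino substituent.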